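Pyrimidine Amines as F508del Correctors: Compound 2 to Compound 3

The source may report more compounds than this note shows. Statements on the series, on what has been measured and on what is new or still open speak of the compounds shown alone.

Compound 1 `COc1ccc(CN2CCc3nc(-c4ccccn4)nc(N4CCN(CCN(C)C)CC4)c3C2)cc1`: "not active" (no number reported), no number given.
Compound 2 `COc1ccc(CN2CCc3nc(-c4ccccn4)nc(N4CCN(CC(N)=O)CC4)c3C2)cc1`: 35.9%

In an assay on FRT cells with Cystic fibrosis transmembrane conductance regulator variant F508del (Homo sapiens) as the target, read by fluorescence, with a stated time of 25 min (on this read-out lower numbers stand for smaller maximal responses and higher numbers for larger maximal responses), compound 2 gives 35.9%, the only number shown; compound 1 was reported as "not active" (no number reported) without a value. Compound 3 `CCN(C(C)=O)C1CCN(c2nc(-c3ccccn3)nc3c2CN(Cc2ccc(OC)cc2)CC3)C1` has not yet been measured. It differs from compound 2 by 3-(acetyl(ethyl)amino)pyrrolidin-1-yl in place of 4-(carbamoylmethyl)piperazin-1-yl on an aromatic carbon. Going by the values given here, no step between measured compounds is known, so the size of the change is uncertain; a step of a number 5.9 percentage points lower from compound 2 to compound 3 (within the scatter) is expected, not beyond the scatter. Compound 3 is estimated at 30%, from 5% to 60%.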

Compound 3, largest response reached (Emax), in percent of the reference or control that the assay uses: 36.9%
Compound 3: the middle estimate sits 6.9 percentage points below what was measured; low and high end bracket the measured number.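

In this assay, putting 3-(acetyl(ethyl)amino)pyrrolidin-1-yl in place of 4-(carbamoylmethyl)piperazin-1-yl on this aromatic carbon gives a number 1 percentage points higher from compound 2 to compound 3 (within the scatter) and shows that a measurable response at this place does not need the piperazine ring or the primary amide. The entering group has a five-membered ring and no hydrogen-bond donors, and the two read alike. Nothing measured here explains this result. The compounds shown leave open whether a free amine in place of the acetyl(ethyl)amino group, or a propyl chain in place of its ethyl, would give a different maximal response.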